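Swapping propyl for 3-methoxyphenyl on the shared core

The source may hold more compounds than are shown below. What is called first, only, known or untested is meant among the compounds shown, and "the series" means these compounds.

Working notes on the series, with all values taken from a functional assay on HT-29 cells (Homo sapiens) for antiproliferative activity, read by MTT assay, with a stated time of 72 h; a lower number here means a stronger inhibitor, a higher number a weaker inhibitor. Compound 1 (`CCCn1ccnc1-c1cc(OC)c(OC)c(OC)c1`) gives > 100000 nM, which is a limit of the assay and not a number. Compound 2 (`COc1cc(-c2nccn2-c2ccc3sccc3c2)cc(OC)c1OC`) gives a true number, 1500 nM. Within the data shown here, no step between measured compounds is available, so the two values offer only a loose guide.

Compound 3 (`COc1cccc(-n2ccnc2-c2cc(OC)c(OC)c(OC)c2)c1`) has 3-methoxyphenyl in place of propyl on an aromatic nitrogen. In this assay, among the measured compounds shown here, a drop in the number beyond the scatter is expected, and compound 2 at 1500 nM is the only measured number to anchor that expectation. The change is estimated as an at least 25-fold lower number from compound 1 to compound 3 (1.39 log units; beyond the scatter). A return to a limit remains possible. The expected value for compound 3 is 4000 nM, with an estimated range of 500 nM to 30000 nM.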

Compound 3, half-maximal inhibitory concentration: 18900 nM
Estimate against measurement, compound 3: 4.7-fold (0.67 log units) below; low and high end bracket the measured number.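

In this assay, 3-methoxyphenyl in place of propyl on the aromatic nitrogen brings the shared core to a true number: compound 3 gives 18900 nM. Among these compounds, this is the first direct reading of a change at this position, an at least 5.2-fold lower number from compound 1 to compound 3 (0.72 log units; beyond the scatter), and the printed size is only a minimum for the step. The value of compound 1 is a limit of the assay and not a number: the limit of > 100000 nM in this assay, at which 1 of the 3 values shown sits.

As far as these compounds go, whether the six-membered aromatic ring alone carries the step, or the methoxy group on it adds to it, stays open, as does what a plain phenyl or a benzyl group would give on this nitrogen. From the compounds shown here alone, it is also open whether a longer chain than propyl would leave the limit behind without any ring at all.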